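Butyl for thiazole at the ring carbon of compound 2

The source may report more compounds than this note shows. Statements on the series, on what has been measured and on what is new or still open speak of the compounds shown alone.

Compound 2 `CC(C)CCn1nc(-c2nccs2)c(O)c(C2=NS(=O)(=O)c3cc(OCC(N)=O)ccc3N2)c1=O` is the starting point of the step considered here. In an in vitro ADME assay on microsomes from liver (Homo sapiens) for metabolic stability (a lower number here means that the compound disappears faster, a higher number that the compound lasts longer), compound 2 gives only a limit, > 1 h. Its neighbours are compound 1 `CC(C)CCn1nc(-c2cccs2)c(O)c(C2=NS(=O)(=O)c3cc(OCC(N)=O)ccc3N2)c1=O` and compound 3 `NC(=O)COc1ccc2c(c1)S(=O)(=O)N=C(c1c(O)c(-c3nccs3)nn(CC3CCC3)c1=O)N2`. In this assay compound 1 gives 0.383 h. Compound 3 also gives only a limit in this assay, > 1 h. Of the three values shown, two sit at the limit (the limit of > 1 h in this assay, at which 2 of the 3 values shown sit), so compound 2 can only be placed at or above the upper edge of what is readable here, not at a number.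

The new compound is compound 4 `CCCCc1nn(CCC(C)C)c(=O)c(C2=NS(=O)(=O)c3cc(OCC(N)=O)ccc3N2)c1O`. The change from compound 2 is butyl in place of 1,3-thiazol-2-yl on an aromatic carbon. For the measured compounds named here, only one measured step bears on this position: an at least 2.6-fold higher number from compound 1 to compound 2 (0.41 log units; beyond the scatter). The step that the two limits leave unreadable from compound 2 to compound 3 concerns another position and gives no readable size. The thiazole that is now removed was the group whose arrival raised the number from compound 1 to compound 2; its replacement by butyl has no measured parallel. For compound 4 a step of an at least 1.4-fold lower number from compound 2 to compound 4 (0.15 log units; that floor lies within the scatter) is therefore expected, downward and uncertain in size. Compound 4 is estimated at 0.7 h, within 0.3 h to 1.5 h.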

Compound 4, half-life: 0.167 h
Compound 4: middle estimate off by 4.2-fold (0.62 log units), on the high side, outside the stated range (below it).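

In this assay, the aromatic carbon next to the ring nitrogen is not indifferent to its substituent: butyl gives a lower number than either five-membered aromatic ring, with an at least 5.9-fold lower number from compound 2 to compound 4 (0.77 log units; beyond the scatter) and a 2.3-fold lower number from compound 1 to compound 4 (0.36 log units; beyond the scatter). For the compounds shown here, the earlier compounds compared only two aromatic rings at this carbon; the open chain now shows that even thiophen-2-yl, the lower of the two, stands above butyl. The first of these steps gives only a floor for the size of the change, as one of its ends is a limit: the limit of > 1 h in this assay, at which 2 of the 4 values shown sit.

From the compounds shown here alone, whether the lower number follows from losing the ring or from the length of the butyl chain remains open. A phenyl ring or a shorter chain such as ethyl at this carbon would separate these two readings.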